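Chain-extended aryl amide on the shared core

This account rests on a few compounds, and the source may have more. Where it says the series, first, only, none or still open, it means among the compounds named here.

Three amides of the shared core carry the same valine-derived right-hand part and differ only in the acyl group. In an assay on THP-1 cells for displacement of a labelled ligand from C-C chemokine receptor type 1 (Homo sapiens) (on this read-out lower numbers stand for stronger inhibition and higher numbers for weaker inhibition), compound 1 `Cc1ccccc1C(=O)N[C@@H](C(=O)N1CCC(c2ccc(Cl)cc2)CC1)C(C)C` gives 32 nM. Compound 2 `CC(C)CC(=O)N[C@@H](C(=O)N1CCC(c2ccc(Cl)cc2)CC1)C(C)C` gives 32 nM in this assay, and the step of no change at the digits printed from compound 1 to compound 2 (within the scatter) lies within the scatter. Compound 3 `CC(C)[C@@H](NC(=O)CCc1ccc(F)cc1)C(=O)N1CCC(c2ccc(Cl)cc2)CC1` gives 70 nM in this assay, the highest of the three numbers; the steps of a 2.2-fold higher number from compound 1 to compound 3 (0.34 log units; beyond the scatter) and a 2.2-fold higher number from compound 2 to compound 3 (0.34 log units; beyond the scatter) are both modest but beyond the scatter.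

Compound 4 `CC(C)[C@@H](NC(=O)CCCc1ccccc1)C(=O)N1CCC(c2ccc(Cl)cc2)CC1` has not been measured. It differs from compound 3 by benzyl in place of 4-fluorophenyl on a saturated chain carbon, two bonds along the chain from a carbonyl carbon; the same difference, cut one bond further out, reads 2-(4-fluorophenyl)ethyl to 3-phenylpropyl. Within the data shown here, no measured step removes a fluorine or lengthens this chain by one carbon, so the only guide is that the acyl changes seen so far move the number by modest amounts at most. The step of no change at the digits printed from compound 3 to compound 4 (within the scatter) is therefore expected to be small, in no firm direction. Compound 4 is estimated at 70 nM, with a range of 30 nM to 160 nM.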

Compound 4, half-maximal inhibitory concentration: 95 nM
The estimate for compound 4 lay 1.4-fold (0.13 log units) below the measured number; measured number inside the range.
By their numbers in this assay, from the lowest: compounds 1 and 2 (each within the scatter of the next); then compounds 3 and 4 (each within the scatter of the next).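

In this assay, benzyl in place of 4-fluorophenyl at this place gives a 1.4-fold higher number from compound 3 to compound 4 (0.13 log units; within the scatter), so the fluorine-free 3-phenylpropyl amide and the 2-(4-fluorophenyl)ethyl amide cannot be told apart on this read-out. Both steps from the two lowest numbers to the new amide are modest but real: a 3.0-fold higher number from compound 2 to compound 4 (0.47 log units; beyond the scatter) and a 3.0-fold higher number from compound 1 to compound 4 (0.47 log units; beyond the scatter). The gap that compound 3 opened to compound 1 and compound 2 therefore also appears in an amide without fluorine, so among these compounds it does not depend on that atom.

No evidence at hand accounts for these steps. Still open, as far as these compounds go, is how the number responds to a carboxylic acid or an amine at the end of the acyl chain, or to a longer chain than 3-phenylpropyl.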